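From 2-bromophenyl to 3-hydroxyphenyl: estimating growth inhibition

A few compounds are considered here, and "the series" means these few. Any claim that something is new, unique, unknown or untested is made for them only; others in the source may bear on it.

In a functional assay on MDA-MB-231 cells (Homo sapiens) for inhibition, read by MTT assay, with a stated time of 48 h (a higher number here means a weaker inhibitor of growth, a lower number a stronger inhibitor of growth), compound 1 (`S=C(NCc1ccccc1)Nc1ccc2ncnc(Nc3ccccc3Br)c2c1`) gives > 30000 nM, which is a limit of the assay and not a number.

Two relatives sharing the core of compound 1 have measured numbers: compound 2 (`Cc1cccc(Nc2ncnc3ccc(NC(=S)NCc4ccccc4)cc23)c1C`) gives 28700 nM and compound 3 (`CC(C)c1ccc(Nc2ncnc3ccc(NC(=S)NCc4ccccc4)cc23)cc1`) gives 12800 nM. Compound 4 (`Oc1cccc(Nc2ncnc3ccc(NC(=S)NCc4ccccc4)cc23)c1`) carries 3-hydroxyphenyl in place of 2-bromophenyl on a nitrogen on an aromatic ring.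

The measured steps at this same place are an at least 1.0-fold lower number from compound 1 to compound 2 (0.01 log units; that floor lies within the scatter), an at least 2.3-fold lower number from compound 1 to compound 3 (0.36 log units; beyond the scatter) and a 2.2-fold lower number from compound 2 to compound 3 (0.35 log units; beyond the scatter). These steps are small, and the first has a floor that lies within the scatter. For the measured compounds named here, none of the measured compounds carries 3-hydroxyphenyl, so they offer only a rough guide.

The step expected in this assay is an at least 1.7-fold lower number from compound 1 to compound 4 (0.24 log units; that floor lies within the scatter), a modest one towards a lower number. For compound 4 the estimated value is 17000 nM, with an expected range of 7000 nM to 35000 nM.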

Compound 4, concentration for 50% growth inhibition: > 30000 nM
Compound 4: no number, only a limit; the forecaster's own chance of this, stated with the estimate: 25%; at least 1.7-fold (0.24 log units) between middle value and limit.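

In this assay compound 4 gives > 30000 nM, which is a limit of the assay and not a number. The step between compound 1 and compound 4 cannot be read, because both compounds stop at a limit: the limit of > 30000 nM in this assay, at which 2 of the 4 values shown sit. Against 4-isopropylphenyl, the change to 3-hydroxyphenyl gives an at least 2.3-fold higher number from compound 3 to compound 4 (0.36 log units; beyond the scatter), while against 2,3-dimethylphenyl it gives an at least 1.0-fold higher number from compound 2 to compound 4 (0.01 log units; that floor lies within the scatter), so on this position only the 4-isopropylphenyl group stands apart from the other three.

From the compounds shown here alone, how far the true values of compound 1 and compound 4 lie from the limit stays open. Also open, going by these compounds, is whether an amine or a carboxylic acid on this phenyl ring, or a tert-butyl group in place of the isopropyl group, would give a lower number than compound 3 does.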